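Triazole substituent swap on the diol lactone series

The source may hold more compounds than are shown below. What is called first, only, known or untested is meant among the compounds shown, and "the series" means these compounds.

Two members of the series have been examined in a functional assay on SW-620 cells (Homo sapiens) for antiproliferative activity, read by MTT assay, with a stated time of 72 h; a lower number here means a stronger inhibitor, a higher number a weaker inhibitor. Compound 1 `CCCCCc1ccc(-c2cn(C/C=C3\OC(=O)C(OCc4ccccc4)=C3OCc3ccccc3)nn2)cc1` gives only a limit in this assay, > 100000 nM, and not a number. Compound 2 `O=C1O[C@H]([C@@H](O)Cn2cc(CNS(=O)(=O)c3ccc(F)cc3)nn2)C(OCc2ccccc2)=C1OCc1ccccc1` gives 41100 nM in this assay. Within the data shown here, compound 2 therefore carries the only numeric reading so far; the single other reading is the limit of the assay, (the limit of > 100000 nM in this assay, at which 1 of the 2 values shown sits), so no ordering between the two can be made from what is known. Among the measured compounds shown here, no step between measured compounds is available.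

Compound 3 `O=C1O[C@H]([C@@H](O)Cn2cc(-c3cc(F)cc(F)c3)nn2)C(OCc2ccccc2)=C1OCc1ccccc1` is the next member. It differs from compound 2 by 3,5-difluorophenyl in place of (((4-fluorophenyl)sulfonyl)amino)methyl on an aromatic carbon, with the rest of the shared core unchanged. Without a measured step on this kind of change, the expectation is a step of a 1.2-fold lower number from compound 2 to compound 3 (0.07 log units; within the scatter), which is within the scatter of repeated measurements in this assay, with a real chance that the assay again reports only a limit. Compound 3 is accordingly estimated at 35000 nM, within a range of 9000 nM to 130000 nM.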

Compound 3, half-maximal inhibitory concentration: > 100000 nM
Compound 3 was reported as a limit (the forecaster's own chance of this, stated with the estimate: 30%); middle value at least 2.8-fold (0.45 log units) from the limit.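

Among these compounds, on the aromatic carbon of the five-membered ring with 3 nitrogen, the change from (((4-fluorophenyl)sulfonyl)amino)methyl to 3,5-difluorophenyl gives the first readable step in this assay for this series: an at least 2.4-fold higher number from compound 2 to compound 3 (0.38 log units; beyond the scatter). Both groups carry a six-membered aromatic ring of carbon only, so in this one pair such a ring on this carbon does not by itself keep a numeric reading, and only the group with the sulfonyl amino link does. Compound 3 gives > 100000 nM, which is a limit and not a number, and the series now rests largely on that limit: the limit of > 100000 nM in this assay, at which 2 of the 3 values shown sit.

One pair cannot separate the parts of the leaving group, so the sulfonyl unit, the amino hydrogen, the methyl link and the ring fluorine remain unresolved as carriers of the reading. Going by these compounds, how a plain aminomethyl group or a carboxamide on the same aromatic carbon would read in this assay stays open, as does whether any group at this position can bring the number well below that of compound 2.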